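The source may hold more compounds than are shown below. What is called first, only, known or untested is meant among the compounds shown, and "the series" means these compounds.

Within the data shown here, in a functional assay on RPMI-8226 cells (Homo sapiens) for antiproliferative activity, read by radiometric assay, with a stated time of 72 h (on this read-out higher numbers stand for weaker inhibition and lower numbers for stronger inhibition), compound 1 `Cc1ccccc1Nc1ncnc2cc(NC(=O)CCCCCCC(=O)NO)sc12` gives 1750 nM while compound 2 `C#Cc1cccc(Nc2ncnc3cc(NC(=O)CCCCCCC(=O)NO)sc23)c1` gives 970 nM so compound 2 sits within the scatter of the only other compound measured. Compound 3 `COc1ccc(Nc2ncnc3cc(NC(=O)CCCCCCC(=O)NO)sc23)cc1` carries 4-methoxyphenyl in place of 3-ethynylphenyl on a nitrogen on an aromatic ring. Among the measured compounds shown here, the only measured step (a 1.8-fold lower number from compound 1 to compound 2 (0.26 log units; within the scatter)) also swapped the group at that nitrogen and stayed within the scatter, so one swap offers thin guidance and no change beyond the scatter is expected here. The estimated step (a 1.2-fold higher number from compound 2 to compound 3 (0.09 log units; within the scatter)) has no clear direction. For compound 3 the estimate is 1200 nM with an expected range from 400 nM to 3500 nM on this read-out.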

Compound 3, half-maximal inhibitory concentration: 1840 nM
For compound 3 the middle estimate is 1.5-fold (0.19 log units) below the measured one; measured number inside the range.
By their numbers in this assay, from the lowest: compounds 2, 1 and 3 (each within the scatter of the next).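

At this nitrogen on the shared core, 4-methoxyphenyl brings in an oxygen and a hydrogen-bond acceptor, yet this assay shows a 1.9-fold higher number from compound 2 to compound 3 (0.28 log units; within the scatter) and a 1.1-fold higher number from compound 1 to compound 3 (0.02 log units; within the scatter). All three groups tried at this position therefore lie within the scatter of one another, so the added acceptor shows no measurable effect here. No evidence is available to explain this result. Still open, going by these compounds, is whether a cyclohexyl ring at this nitrogen, or a phenyl ring carrying a carboxylic acid, would move the number beyond the scatter.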